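A few compounds are considered here, and "the series" means these few. Any claim that something is new, unique, unknown or untested is made for them only; others in the source may bear on it.

Working notes on the series, read in a functional assay on HL-60 cells (Homo sapiens) for antiproliferative activity, read by MTT assay; on this read-out lower numbers stand for stronger inhibition and higher numbers for weaker inhibition. Compound 1 `O[C@@H]1[C@@H](OCc2ccccc2)[C@H](OCc2ccccc2)[C@@H](COCc2ccccc2)O[C@@H]1CC1CCCCC1` gives 17200 nM, the higher of the two numbers available. Compound 2 `O[C@@H]1[C@@H](OCc2ccccc2)[C@H](OCc2ccccc2)[C@@H](COCc2ccccc2)O[C@H]1CC1CCCCC1` gives 4100 nM. Compound 3 `C#CC[C@@H]1O[C@H](COCc2ccccc2)[C@@H](OCc2ccccc2)[C@H](OCc2ccccc2)[C@H]1O` is recorded as "not active" (no number reported), so it offers no number for comparison.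

Compound 4 `C=C[C@H]1O[C@H](COCc2ccccc2)[C@@H](OCc2ccccc2)[C@H](OCc2ccccc2)[C@H]1O` is still to be measured. Its change from compound 1 is vinyl in place of cyclohexylmethyl on a saturated ring carbon: vinyl replaces cyclohexylmethyl on a saturated ring carbon, and the rest of the core stays the same.

Among the compounds with values here, only one measured step exists, a 4.2-fold lower number from compound 1 to compound 2 (0.62 log units; beyond the scatter), and it comes with the fact that compounds 1 and 2 differ only in the configuration as drawn. It shows that this ring carbon is not indifferent to change, but it is a change of configuration only and gives no direct measure for swapping the substituent. Its modest size serves only as a rough guide. The closest indication of direction is compound 3, at "not active" (no number reported), which suggests that activity in this assay may not survive without the cyclohexylmethyl group.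

A weaker result is therefore expected, possibly with no number reported at all. The expected step is a 1.7-fold higher number from compound 1 to compound 4 (0.24 log units; within the scatter). For compound 4 the estimated value is 30000 nM, with an expected range of 12000 nM to 80000 nM.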

Compound 4, half-maximal inhibitory concentration: "not active" (no number reported)
The entry for compound 4 holds no number, so the estimate cannot be set against anything.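

Within the data shown here, compound 4 is recorded as "not active" in this assay with no number, so no step from compound 1 to compound 4 can be read. The compounds shown leave open how far activity at this saturated ring carbon depends on cyclohexylmethyl, and whether any smaller group there would give a number. Nothing shown bears on why compound 4 gives this result.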